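A few compounds are considered here, and "the series" means these few. Any claim that something is new, unique, unknown or untested is made for them only; others in the source may bear on it.

Measured in a physicochemical assay for solubility, in phosphate buffer, at pH 7.4; on this read-out higher numbers stand for higher solubility and lower numbers for lower solubility:
- compound 1 `CCOC(=O)c1c(-c2ccc(C(F)(F)F)cc2)[nH]c2cccc(OC)c2c1=O`: 22000 nM
- compound 2 `CCOC(=O)c1c(-c2cccc(F)c2)[nH]c2cc(OC)ccc2c1=O`: > 100000 nM
- compound 3 `CCOC(=O)c1c(-c2cccc(OC)c2)[nH]c2cc(OC)ccc2c1=O`: > 100000 nM

Among the measured compounds shown here, compound 1 holds the only true number in this set, 22000 nM. Compound 2 reads > 100000 nM, which is a limit of the assay and not a number. Compound 3 reads > 100000 nM, and this too is a limit. Both sit at the same ceiling (the limit of > 100000 nM in this assay, at which 2 of the 3 values shown sit), so a step that the two limits leave unreadable from compound 2 to compound 3 offers no size to carry over. That step also swaps methoxy for fluoro, a different change from the one at issue here.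

Compound 4 `CCOC(=O)c1c(-c2ccccc2)[nH]c2cccc(OC)c2c1=O` is still unmeasured. It has hydrogen in place of trifluoromethyl on an aromatic carbon, para to a large group (hydrogen in place of trifluoromethyl on an aromatic carbon). For the measured compounds named here, no measured step makes this exact change, so the expectation is only a rough one. Compound 2 and compound 3 also differ from compound 1 in more than this one place, but neither carries a trifluoromethyl, and both stand at the limit (the limit of > 100000 nM in this assay, at which 2 of the 3 values shown sit). On that thin basis, a rise in this assay beyond the usual scatter is expected, estimated as a 2.7-fold higher number from compound 1 to compound 4 (0.44 log units; beyond the scatter). For compound 4 the estimated value is 60000 nM, with an expected range from 25000 nM to 100000 nM.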

Compound 4, solubility: > 100000 nM
Compound 4 was reported as a limit; the forecaster's own chance of this, stated with the estimate: 30%; middle value at least 1.6-fold (0.22 log units) from the limit.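

Before this result, no two compounds differing in one place gave a step of readable size in this assay, so nothing yet spoke to this position. Compound 1 and compound 4 now supply that pair: they differ only at one aromatic carbon, para to a large group, where trifluoromethyl leaves and hydrogen enters, and this single change gives an at least 4.5-fold higher number from compound 1 to compound 4 (0.65 log units; beyond the scatter). Compound 4 reads > 100000 nM, which is a limit and not a number, so the step has a lower end but no upper end: the limit of > 100000 nM in this assay, at which 3 of the 4 values shown sit.

Among the compounds shown here, how far compound 4 truly lies from compound 1 stays unknown, and the same change has been seen only on this one core, with the methoxy placed as in compound 1 and compound 4. From the compounds shown here alone, it also remains open what an amine or a carboxylic acid would give on this same aromatic carbon, and a step of full size could be read only if such a compound gave a true number in this assay rather than a limit.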